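This account rests on a few compounds, and the source may have more. Where it says the series, first, only, none or still open, it means among the compounds named here.

In a functional assay on J774 cells (Mus musculus) for cytotoxicity, read by resazurin assay, with a stated time of 72 h (on this read-out higher numbers stand for weaker inhibition and lower numbers for stronger inhibition), compound 1 `O=S(=O)(Nc1cccc(CO)c1)c1ccc(-c2ccc(C(F)(F)F)cc2)cc1` gives 2500 nM and compound 2 `O=S(=O)(Nc1cccc(CO)c1)c1ccc(-c2ccc(Cl)cc2)cc1` gives 2500 nM, which leaves compound 2 level with compound 1. Compound 3 `O=S(=O)(Nc1cccc(CO)c1)c1ccc(-c2ccc(Cl)cc2F)cc1` differs from compound 2 by fluoro in place of hydrogen on an aromatic carbon. Among the measured compounds shown here, the one measured step, no change at the digits printed from compound 1 to compound 2 (within the scatter), is a chloro in place of trifluoromethyl, and no measured step shows fluoro entering, so it bears only loosely. Nothing beyond the scatter is therefore expected in this assay. The estimated step is a 1.1-fold lower number from compound 2 to compound 3 (0.04 log units; within the scatter). Compound 3 is expected at 2300 nM, within a range of 1100 nM to 4800 nM.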

Compound 3, half-maximal inhibitory concentration: 700 nM
Compound 3: middle estimate off by 3.3-fold (0.52 log units), on the high side; the measured number lies below the stated range.
By their numbers in this assay, from the lowest: compound 3; then compounds 1 and 2 (each within the scatter of the next).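

In this assay, among the compounds shown here, the change from 4-chlorophenyl to 4-chloro-2-fluorophenyl gives a 3.6-fold lower number from compound 2 to compound 3 (0.55 log units; beyond the scatter) and is the first step here beyond the scatter. The earlier chloro in place of trifluoromethyl gave no change at the digits printed from compound 1 to compound 2 (within the scatter) and so showed no sensitivity to that change, whereas a single fluoro ortho to a large group does move the number. No evidence at hand accounts for this shift. On these data alone, whether a methoxy group or an amine at this same place would move the number as well remains open, as does the effect of fluoro elsewhere on this ring.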